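The source may report more compounds than this note shows. Statements on the series, on what has been measured and on what is new or still open speak of the compounds shown alone.

Measured compounds in a functional assay on cardiac atrium for agonist activity at histamine H2 receptor (Cavia porcellus); a higher number here means a larger maximal response, a lower number a smaller maximal response:
Compound 1 `N=C(NCCCc1c[nH]cn1)NCCCC(c1ccccc1)c1ccccn1` gives 1.
Compound 2 `N=C(NCCCc1c[nH]cn1)NCCC(c1ccccc1)c1ccccn1` gives 1.
Compound 3 `N=C(NCCCc1c[nH]cn1)NCCC(c1ccc(Cl)cc1)c1ccccn1` gives 1.

In this assay compound 3 stands level with compound 1 and compound 2 at the digits printed; each of the three reaches the same maximal response as the reference agonist. Among the measured compounds shown here, the one single-point step among the measured compounds, no change at the digits printed from compound 2 to compound 3 (within the scatter), is flat within the scatter, so chloro in place of hydrogen on an aromatic carbon left the maximal response where it was. Compound 1 and compound 3 differ at more than one place; their values show nothing either.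

Compound 4 `N=C(NCCCc1c[nH]cn1)NCCC(c1ccc(C(F)(F)F)cc1)c1ccccn1` is the next member. Relative to compound 3 the change is trifluoromethyl in place of chloro on an aromatic carbon, on an aromatic carbon of a six-membered aromatic ring of carbon only, para to a large group. For the measured compounds named here, the only step that bears on it is the one from compound 2 to compound 3 at the same position, and that was flat; the series so far has not moved off the ceiling set by the reference agonist. No step beyond the scatter is therefore expected, and the step from compound 3 to compound 4 is estimated as no change at the digits printed from compound 3 to compound 4 (within the scatter). For compound 4 the expected value in this assay is 1, with a range of 0.85 to 1.05.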

Compound 4, intrinsic activity: the largest response reached, as a fraction of the reference agonist's: 0.9
Estimate against measurement, compound 4: 0.10 above, within the range that was stated.
By their numbers in this assay, from the lowest: compounds 4, 1, 2 and 3 (each within the scatter of the next).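

In this assay the aromatic carbon para to a large group now carries a second substituent, trifluoromethyl, with 4 heavy atoms where chloro has 1: the change gives a number 0.10 lower from compound 3 to compound 4 (within the scatter) and, measured against hydrogen, a number 0.10 lower from compound 2 to compound 4 (within the scatter) at this position. Neither step can be read as a loss of maximal response, so at this position the flat result no longer rests on chloro alone. Nothing measured here speaks to what lies behind the small difference in the printed numbers.

As far as these compounds go, an amine or a carboxylic acid at this same aromatic carbon remains open, as does whether either would hold the maximal response at the level seen so far. Also open, from the compounds shown here alone, is whether chloro or trifluoromethyl would read the same on the longer chain of compound 1.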